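Chain lengthened by one carbon in the cyanoguanidine series

The source may report more compounds than this note shows. Statements on the series, on what has been measured and on what is new or still open speak of the compounds shown alone.

Within the data shown here, compound 2 `N#C/N=C1\N(CCCCCCOc2ccc(Cl)cc2)C(=O)C(c2ccccc2)N1c1ccncc1` gives 1130 nM in a functional assay on MCF7 cells (Homo sapiens) for cytotoxicity (a higher number here means a weaker inhibitor, a lower number a stronger inhibitor), the higher of the two numbers measured so far. Among the measured compounds shown here, compound 1 `CC1C(=O)N(CCCCCCCOc2ccc(Cl)cc2)/C(=N\C#N)N1c1ccncc1` gives 460 nM in this assay and sits beyond the scatter below compound 2, but the two differ in two places, so no single step between them can be read. Compound 3 `N#C/N=C1\N(CCCCCCCOc2ccc(Cl)cc2)C(=O)C(c2ccccc2)N1c1ccncc1` carries (4-chlorophenoxy)methyl in place of 4-chlorophenoxy on a saturated chain carbon, six bonds along the chain from an amide-type nitrogen in a ring. For the measured compounds named here, no measured pair isolates this change. In this assay the step of a 1.4-fold lower number from compound 2 to compound 3 (0.15 log units; within the scatter) is expected to be small, at most a modest lowering. Compound 3 is estimated at 800 nM, within 300 nM to 2500 nM.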

Compound 3, half-maximal inhibitory concentration: 1170 nM
Compound 3: middle estimate off by 1.5-fold (0.17 log units), on the low side; low and high end bracket the measured number.
By their numbers in this assay, from the lowest: compound 1; then compounds 2 and 3 (each within the scatter of the next).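

In this assay, (4-chlorophenoxy)methyl in place of 4-chlorophenoxy on the saturated chain carbon gives a 1.0-fold higher number from compound 2 to compound 3 (0.02 log units; within the scatter), so with phenyl on the saturated ring carbon, this added carbon leaves the read-out within the scatter. With the chain held fixed, phenyl in place of methyl on that ring carbon gives a 2.5-fold higher number from compound 1 to compound 3 (0.41 log units; beyond the scatter), a modest step beyond the scatter. No evidence at hand accounts for either step. As far as these compounds go, whether the chain step would look the same with methyl on the ring carbon remains open. So does the effect of a longer chain, or of an amine or a carboxylic acid on the ring carbon.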